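Small Branched Alkyl on the Ring Nitrogen: Compound 4

The compounds below may be only part of what the source reports. "The series", "measured", "known", "first", "only" and "open" are said of these compounds alone.

Measured compounds:
Compound 1 `CC(C)c1onc(-c2c(Cl)cccc2Cl)c1COc1ccc(-c2nc3ccc(C(=O)O)cc3n2C2CC2)cc1` gives 3200 nM in an assay on HEK-293T cells for antagonist activity at vitamin D3 receptor (Homo sapiens), read by a luciferase reporter, with a stated time of 24 h; on this read-out higher numbers stand for weaker inhibition and lower numbers for stronger inhibition.
Compound 2 `CCCC(CCC)n1c(-c2ccc(OCc3c(-c4c(Cl)cccc4Cl)noc3C(C)C)cc2)nc2ccc(C(=O)O)cc21` gives a result in this assay that is a limit of the assay rather than a number, > 10000 nM.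
Compound 3 `CC(C)c1onc(-c2c(Cl)cccc2Cl)c1COc1ccc(-c2nc3ccc(C(=O)O)cc3n2CC2CC2)cc1` gives 2650 nM in this assay.

Among the numbers shown, compound 3 stands lowest of the two, with compound 1 a close neighbour: a 1.2-fold lower number from compound 1 to compound 3 (0.08 log units; within the scatter), a gap within the scatter. The 1-propylbutyl compound sits at the assay limit (the limit of > 10000 nM in this assay, at which 1 of the 3 values shown sits).

Compound 4 `CC(C)c1onc(-c2c(Cl)cccc2Cl)c1COc1ccc(-c2nc3ccc(C(=O)O)cc3n2C(C)C)cc1` differs from compound 3 in one place: isopropyl in place of cyclopropylmethyl on an aromatic nitrogen. Within the data shown here, two measured steps bear on it. Exchanging cyclopropyl for cyclopropylmethyl changed little, a 1.2-fold lower number from compound 1 to compound 3 (0.08 log units; within the scatter), whereas the large 1-propylbutyl group pushed the number beyond the limit, an at least 3.7-fold lower number from compound 2 to compound 3 (0.57 log units; beyond the scatter). Isopropyl is small, like the groups of compound 1 and compound 3, so no step beyond the scatter is expected: a 1.1-fold higher number from compound 3 to compound 4 (0.05 log units; within the scatter). Compound 4 is therefore estimated at 3000 nM, expected between 1200 nM and 8000 nM.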

Compound 4, half-maximal inhibitory concentration: 3550 nM
Compound 4: middle estimate off by 1.2-fold (0.07 log units), on the low side, within the range that was stated.
By their numbers in this assay, from the lowest: compounds 3, 1 and 4 (each within the scatter of the next). At a limit, above all of these: compound 2.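

Isopropyl has no ring, yet on the aromatic nitrogen it stays level with both ring-bearing groups (a 1.3-fold higher number from compound 3 to compound 4 (0.13 log units; within the scatter); a 1.1-fold higher number from compound 1 to compound 4 (0.05 log units; within the scatter)), so among these compounds a three-membered ring at this position is not needed to hold the number. Branching at the carbon on the nitrogen also does not by itself separate these compounds, since isopropyl and 1-propylbutyl share it and yet stand apart (an at least 2.8-fold lower number from compound 2 to compound 4 (0.44 log units; beyond the scatter)). Compound 2 gives a limit of the assay rather than a number: the limit of > 10000 nM in this assay, at which 1 of the 4 values shown sits.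

The compounds shown leave open where the number begins to rise on the way from isopropyl to 1-propylbutyl, for instance with 1-ethylpropyl or cyclohexyl on the aromatic nitrogen. They also leave open how a chain ending in an amine or a hydroxyl group would read at this position.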